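From 4-cyanophenyl to 2-chloro-4-fluorophenyl

A few compounds are considered here, and "the series" means these few. Any claim that something is new, unique, unknown or untested is made for them only; others in the source may bear on it.

Three compounds share one core: compound 1 `CNC(=O)c1cc(Oc2ccc(C3=NNC(c4ccc(Cl)cc4Cl)C3)cc2)ccn1`, compound 2 `CNC(=O)c1cc(Oc2ccc(C3=NNC(c4cccc(Br)c4)C3)cc2)ccn1` and compound 3 `CNC(=O)c1cc(Oc2ccc(C3=NNC(c4ccc(C#N)cc4)C3)cc2)ccn1`. In a functional assay on HepG2 cells (Homo sapiens) for cytotoxicity, read by MTT assay, with a stated time of 72 h (on this read-out higher numbers stand for weaker inhibition and lower numbers for stronger inhibition), the result for compound 1 is "not determined" (no result reported). There, compound 2 gives 1850 nM. Compound 3 gives 15000 nM, the higher of the two numbers and so the weaker inhibition. Among the compounds with values here, the one measured step, an 8.1-fold higher number from compound 2 to compound 3 (0.91 log units; beyond the scatter), came with 4-cyanophenyl in place of 3-bromophenyl. Compound 4 `CNC(=O)c1cc(Oc2ccc(C3=NNC(c4ccc(F)cc4Cl)C3)cc2)ccn1` has 2-chloro-4-fluorophenyl in place of 4-cyanophenyl on a saturated ring carbon. Within the data shown here, it too gives up 4-cyanophenyl, so compound 2 at 1850 nM is the only guide, and it points to a lower number. The step expected is a 5.0-fold lower number from compound 3 to compound 4 (0.70 log units; beyond the scatter), an estimate resting on a single comparison. For compound 4 the estimate is 3000 nM, with an expected range of 900 nM to 10000 nM.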

Compound 4, half-maximal inhibitory concentration: 11500 nM
Beside the measured number, compound 4's estimate is 3.8-fold (0.58 log units) below it; the whole stated range lies below it.
By their numbers in this assay, from the lowest: compound 2; then compounds 4 and 3 (each within the scatter of the next).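

Leaving 4-cyanophenyl on this saturated ring carbon does not by itself shift the read-out: in this assay the swap to 2-chloro-4-fluorophenyl gives a 1.3-fold lower number from compound 3 to compound 4 (0.12 log units; within the scatter) and so no real change. Against 3-bromophenyl, the same group gives a 6.2-fold higher number from compound 2 to compound 4 (0.79 log units; beyond the scatter) and so compound 2 alone stands apart among the three numbers. Nothing measured here accounts for this.

Open, going by these compounds, is whether a plain phenyl or a 3-methoxyphenyl at this carbon would sit nearer compound 2 or nearer compounds 3 and 4.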